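Cinnamate Esters Compared in a Whole-Animal Screen

The compounds below may be only part of what the source reports. "The series", "measured", "known", "first", "only" and "open" are said of these compounds alone.

Compound 1 `COc1cc(OC)c(OC)cc1/C=C/COC(=O)/C=C/c1ccc(OC)c(OC)c1OC`: 100%
Compound 2 `COc1ccccc1/C=C/C(=O)OC/C=C/c1cc(OC)c(OC)cc1OC`: 100%
Compound 3 `COc1cc(OC)c(OC)cc1/C=C/COC(=O)/C=C/c1cccc(Br)c1`: 100%

Three esters have been measured in a functional assay on the whole organism (strain Kunming) with Mus musculus as the target, with a stated time of 0.5 h, at a dose of 100 mg/kg by the intraperitoneal route; a higher number here means a weaker effect of the compound at the dose given, a lower number a stronger effect. In this assay compound 1 gives 100%, compound 2 gives 100%, and compound 3 gives 100%. Compound 3 therefore stands level with compounds 1 and 2 at the digits reported, and none of the three is separated from another by more than the usual scatter. Among the measured compounds shown here, the one single-point step available, no change at the digits printed from compound 2 to compound 3 (within the scatter), put 3-bromophenyl in place of 2-methoxyphenyl and left the read-out where it was.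

Compound 4 `COc1cccc(/C=C/C(=O)OC/C=C/c2cc(OC)c(OC)cc2OC)c1` has not yet been measured. It differs from compound 3 in one place: methoxy in place of bromo on an aromatic carbon. For the measured compounds named here, the only comparable step is the one from compound 2 to compound 3, which showed nothing beyond the scatter, and every measured compound sits at the same value, so no shift beyond the scatter is expected here either. Compound 4 is therefore estimated at 100%, within 88% to 100%, corresponding to an expected step of no change at the digits printed from compound 3 to compound 4 (within the scatter).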

Compound 4, a percentage reported as activity, at one dose (the size of the read-out at that dose, not a potency): 100%
Compound 4: the middle estimate sits on the measured number at the digits printed; the range from low to high includes it.
By their numbers in this assay, from the lowest: compounds 1, 2, 3 and 4 (each within the scatter of the next).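

At the aromatic carbon meta to a large group, methoxy in place of bromo gave no change at the digits printed from compound 3 to compound 4 (within the scatter) in this assay, so two different groups have now stood at this place with no separation in the read-out. The earlier compounds did not show how the 3-methoxyphenyl compares with the 2-methoxyphenyl, and that change gave no change at the digits printed from compound 2 to compound 4 (within the scatter) in this assay as well, so neither change among these esters separates one compound from another. No measurement is at hand that bears on why these changes leave the read-out where it stands.

The compounds shown leave open whether an amine or a carboxylic acid at this aromatic carbon would give a different read-out. They also leave open whether a longer chain in the ester part of the core would do so.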